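From 2-Fluorophenyl to 3-Fluorophenyl on a Shared Core

The source may hold more compounds than are shown below. What is called first, only, known or untested is meant among the compounds shown, and "the series" means these compounds.

In an ADME assay on MT4 cells (Homo sapiens) for cytotoxicity, read by MTT assay, with a stated time of 4 days (a higher number here means that more compound is tolerated, a lower number that less compound is tolerated), compound 1 `COc1c(-c2ccccc2)oc2ccc(N)cc2c1=O` gives 126000 nM, and compound 2 `COc1c(-c2ccccc2F)oc2ccc(N)cc2c1=O` gives 234000 nM. Among the compounds with values here, compound 2 therefore stands within the scatter of compound 1, the only other compound measured so far. Compound 3 `COc1c(-c2cccc(F)c2)oc2ccc(N)cc2c1=O` carries 3-fluorophenyl in place of 2-fluorophenyl on an aromatic carbon, so the two have the same atoms, joined differently. Within the data shown here, no measured step covers this change directly. Among the measured compounds shown here, the only step available, a 1.9-fold higher number from compound 1 to compound 2 (0.27 log units; within the scatter), puts fluoro in place of hydrogen on an aromatic carbon and bears on the change only indirectly. For the measured compounds named here, with that small step as the sole guide, the expected change in this assay is a 1.3-fold lower number from compound 2 to compound 3 (0.11 log units; within the scatter), and nothing beyond the scatter is expected. The estimate for compound 3 is 180000 nM, with an expected range from 90000 nM to 350000 nM.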

Compound 3, half-maximal cytotoxic concentration: 113000 nM
The estimate for compound 3 lay 1.6-fold (0.20 log units) above the measured number, within the range that was stated.
By their numbers in this assay, from the lowest: compounds 3, 1 and 2 (each within the scatter of the next, the first and the last beyond it).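

In this assay, within the data shown here, shifting the fluorine gives a 2.1-fold lower number from compound 2 to compound 3 (0.32 log units; beyond the scatter), so the place of the fluorine on this phenyl ring can change the number modestly, a change that the earlier compounds could not show. Against the unsubstituted phenyl, fluoro in place of hydrogen gives a 1.1-fold lower number from compound 1 to compound 3 (0.05 log units; within the scatter), which leaves compound 3 and compound 1 indistinguishable, so only the pair of fluorinated isomers stands apart, and only narrowly. The data offer no measured basis for explaining this difference between the isomers. From the compounds shown here alone, whether a chloro group, a methoxy group or an amine on the same phenyl ring would follow the same dependence on place remains open. Going by these compounds, it also remains open whether this small separation would persist with any other group on the shared core.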